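This account rests on a few compounds, and the source may have more. Where it says the series, first, only, none or still open, it means among the compounds named here.

Measured compounds in an in vitro functional assay on cells for antagonist activity at B1 bradykinin receptor (Homo sapiens), read by luminescence and calcium flux, with a stated time of 2 h; a higher number here means a weaker inhibitor, a lower number a stronger inhibitor:
compound 1, `Cc1ccc(S(=O)(=O)N2C=CNC(=O)[C@H]2CC(=O)N[C@@H]2CCCc3cc(CN4CCCC4)ccc32)cc1`, gives 0.084 nM;
compound 2, `Cc1ccc(S(=O)(=O)N2C=CNC(=O)[C@H]2CC(=O)N[C@H]2CCN(CC(C)(C)C)CC2(C)C)cc1`, gives 1.38 nM;
compound 3, `Cc1cc(S(=O)(=O)N2C=CNC(=O)[C@H]2CC(=O)N2CCC(N(C)C)CC2)c(C)cc1Cl`, gives 152 nM.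

Compound 3 stands with the highest number of the three in this assay, which makes it the weakest inhibitor of this set. Its nearest neighbour is compound 2 and compound 1 lies furthest away, both gaps beyond the usual scatter. The next compound, compound 4, `Cc1cc(S(=O)(=O)N2C=CNC(=O)[C@H]2CC(=O)N2C[C@H]3CN(C)C[C@H]3C2)c(C)cc1Cl`, differs from compound 3 in one place: a group of 9 heavy atoms (7 carbon, 2 nitrogen; 2 five-membered non-aromatic rings with 1 hetero atom each) in place of a group of 9 heavy atoms (7 carbon, 2 nitrogen; one six-membered non-aromatic ring with 1 hetero atom), on a carbonyl carbon. No measured pair isolates such a change, so its size cannot be read off from the numbers shown. The expected step, a 1.3-fold higher number from compound 3 to compound 4 (0.12 log units; within the scatter), is small, in no sure direction, and not beyond the scatter. Compound 4 is therefore estimated at 200 nM, with a range from 50 nM to 800 nM.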

Compound 4, half-maximal inhibitory concentration: 136 nM
Beside the measured number, compound 4's estimate is 1.5-fold (0.17 log units) above it; the range from low to high includes it.
By their numbers in this assay, from the lowest: compound 1; then compound 2; then compounds 4 and 3 (each within the scatter of the next).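

In this assay, the 4-(dimethylamino)piperidin-1-yl group on the carbonyl carbon of compound 3 gives way to a group with 2 five-membered non-aromatic rings, with a 1.1-fold lower number from compound 3 to compound 4 (0.05 log units; within the scatter). For the compounds shown here, this is the only single-place comparison in the set, and it shows that this position tolerates this exchange of ring groups, with the same heavy atom count, without a change that can be told from the scatter. No supporting measurement bears on this result. Still open, as far as these compounds go, is whether a morpholine or an open-chain 2-(dimethylamino)ethylamino group on this carbonyl carbon would move the number beyond the scatter.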